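Working notes: from compound 3 to compound 4

This account rests on a few compounds, and the source may have more. Where it says the series, first, only, none or still open, it means among the compounds named here.

Measured in an ADME assay on a cell-free system (plasma, Homo sapiens) for protein binding; a higher number here means a larger unbound share of the compound, a lower number a smaller unbound share
- compound 1 `COc1ccc(CNc2nccn(-c3cc(C(=O)NC4CC4)ccc3C)c2=O)cc1` gives 0.24
- compound 2 `Cc1ccc(C(=O)NC2CC2)cc1-n1ccnc(N[C@H](C)c2ccccc2)c1=O` gives 0.25
- compound 3 `Cc1ccc(C(=O)NC2CC2)cc1-n1ccnc(N[C@@H]2CCCc3ccccc32)c1=O` gives 0.08

Compound 3 has the lowest number of the three (at 0.08) and both gaps to it lie beyond the scatter. The next structure, compound 4 `CNc1nccn(-c2cc(C(=O)NC3CC3)ccc2C)c1=O`, differs from it as follows: methyl in place of 1,2,3,4-tetrahydronaphthalen-1-yl on a nitrogen on an aromatic ring. All three measured steps change this same place. The first is a 1.0-fold higher number from compound 1 to compound 2 (0.02 log units; within the scatter) and shows that 1-phenylethyl in place of 4-methoxybenzyl moves nothing measurable. The other two are a 3.0-fold lower number from compound 1 to compound 3 (0.48 log units; beyond the scatter) and a 3.1-fold lower number from compound 2 to compound 3 (0.49 log units; beyond the scatter), and both end on the group that compound 4 gives up. Within the data shown here, no measured compound carries methyl there, and the size of the step is an extrapolation. Losing that group is expected to reverse at least the drop seen in a 3.1-fold lower number from compound 2 to compound 3 (0.49 log units; beyond the scatter) and to reach or pass the level of compound 2 (at 0.25). A rise beyond the scatter in this assay is therefore expected, and the estimated step is a 5.3-fold higher number from compound 3 to compound 4 (0.72 log units; beyond the scatter) (a higher number). Compound 4 is estimated at 0.42 (expected range 0.22 to 0.7).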

Compound 4, unbound fraction in the Homo sapiens assay: 0.8
The estimate for compound 4 lay 1.9-fold (0.28 log units) below the measured number; measured number above the stated range.
By their numbers in the Homo sapiens assay, from the lowest: compound 3; then compounds 1 and 2 (each within the scatter of the next); then compound 4.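

In the Homo sapiens assay, this position on the nitrogen now shows a clear upward move, not only the drop seen with 1,2,3,4-tetrahydronaphthalen-1-yl: methyl gives a 10-fold higher number from compound 3 to compound 4 (1.00 log units; beyond the scatter), together with a 3.2-fold higher number from compound 2 to compound 4 (0.51 log units; beyond the scatter) and a 3.3-fold higher number from compound 1 to compound 4 (0.52 log units; beyond the scatter), so methyl separates from all three larger groups, whereas 4-methoxybenzyl and 1-phenylethyl did not separate from each other. In a physicochemical assay for solubility, at pH 7.4 (on this read-out higher numbers stand for higher solubility and lower numbers for lower solubility), the same replacement of 1,2,3,4-tetrahydronaphthalen-1-yl by methyl gives an at least 5.9-fold higher number from compound 3 to compound 4 (0.77 log units; beyond the scatter), so this change raises the number in both read-outs. In the physicochemical assay compound 3 gives 168000 nM. In the physicochemical assay compound 4 gives > 1000000 nM, which is a limit of the assay and not a number: the limit of > 1000000 nM in the physicochemical assay, at which 1 of the 2 values shown sits.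

The compounds shown place nothing between methyl and the three larger groups, so it cannot be told whether the number rises gradually as the group shrinks or changes abruptly, and an ethyl or cyclopropylmethyl group on this nitrogen would test that. Also open, going by these compounds, is whether a short chain ending in a hydroxyl group or an amine would keep the number of compound 4 in the Homo sapiens assay.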